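Aortic assay series: fluoro variant of compound 2

This account rests on a few compounds, and the source may have more. Where it says the series, first, only, none or still open, it means among the compounds named here.

compound 1 `CC1(C)C=C(n2ccccc2=O)c2cc(OCC(=O)c3ccccc3)ccc2O1`: 5.05
compound 2 `CC1(C)C=C(n2ccccc2=O)c2cc(OC(=O)Nc3ccccc3)ccc2O1`: 5.3

In a functional assay (aorta) with Rattus norvegicus as the target (on this read-out higher numbers stand for higher potency (the scale is a negative logarithm) and lower numbers for lower potency), compound 2 gives 5.3, the higher of the two numbers; compound 1 gives 5.05, and the step of a number 0.25 log units higher from compound 1 to compound 2 (within the scatter) lies within the scatter. Compound 3 `CC1(C)C=C(n2ccccc2=O)c2cc(OC(=O)Nc3ccccc3F)ccc2O1` differs from compound 2 by fluoro in place of hydrogen on an aromatic carbon. For the measured compounds named here, no measured step concerns fluoro in place of hydrogen on the phenyl; the single step known, a number 0.25 log units higher from compound 1 to compound 2 (within the scatter), alters another part of the molecule and does not bear directly on this change. For compound 3, therefore, no shift beyond the scatter is expected in this assay, a number 0.05 log units higher from compound 2 to compound 3 (within the scatter). The estimate for compound 3 is 5.35, from 4.9 to 5.8.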

Compound 3, logarithm of the reciprocal of the active concentration, log(1/C): 5.38
Estimate against measurement, compound 3: 0.03 log units below, and the stated range covers the measured number.
By their numbers in this assay, from the lowest: compounds 1, 2 and 3 (each within the scatter of the next, the first and the last beyond it).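

In this assay, fluoro in place of hydrogen on an aromatic carbon, ortho to a large group, gives a number 0.08 log units higher from compound 2 to compound 3 (within the scatter), so this position takes a fluoro without a shift beyond the scatter. For the compounds shown here, replacing benzoylmethyl with (2-fluorophenyl)carbamoyl gives a number 0.33 log units higher from compound 1 to compound 3 (beyond the scatter), the first step beyond the scatter, though only a modest one. Nothing at hand accounts for either step. Still open, going by these compounds, is whether a chloro, a methoxy or a carboxylic acid at this position would behave as fluoro does. Also open, on these data alone, is how fluoro would behave on the other carbons of this ring.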